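Swapping Chloro for Methyl on the Urea Phenyl Ring

The compounds below may be only part of what the source reports. "The series", "measured", "known", "first", "only" and "open" are said of these compounds alone.

Among the compounds with values here, compound 2 `CN(C)CCNc1nc(-c2ccc(NC(=O)Nc3ccc(Cl)cc3)cc2)nc2ccsc12` gives 130 nM in a functional assay on NCI-H460 cells (Homo sapiens) for cytotoxicity, read by MTT assay, with a stated time of 72 h (a higher number here means a weaker inhibitor, a lower number a stronger inhibitor), the lowest of the two numbers measured so far; compound 1 `CN(C)CCNc1nc(-c2ccc(NC(=O)Nc3ccc(F)cc3)cc2)nc2ccsc12` gives 390 nM. Within the data shown here, the single measured step, a 3.0-fold lower number from compound 1 to compound 2 (0.48 log units; beyond the scatter), exchanged one halogen for another. Compound 3 `Cc1ccc(NC(=O)Nc2ccc(-c3nc(NCCN(C)C)c4sccc4n3)cc2)cc1` differs from compound 2 by methyl in place of chloro on an aromatic carbon. Among the measured compounds shown here, no measured step replaces a halogen with a carbon group, so the halogen step offers no direct guide, and a change within the scatter is the expectation. Compound 3 is therefore expected to give 200 nM, between 70 nM and 600 nM. That estimate means a step of a 1.5-fold higher number from compound 2 to compound 3 (0.19 log units; within the scatter) is expected.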

Compound 3, half-maximal inhibitory concentration: 1880 nM
For compound 3 the middle estimate is 9.4-fold (0.97 log units) below the measured one; the measured number lies above the stated range.
By their numbers in this assay, from the lowest: compound 2; then compound 1; then compound 3.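

Here a halogen gives way to a carbon group: a 14-fold higher number from compound 2 to compound 3 (1.16 log units; beyond the scatter) comes with methyl in place of chloro, and a 4.8-fold higher number from compound 1 to compound 3 (0.68 log units; beyond the scatter) comes with methyl in place of fluoro. The group on this aromatic carbon therefore matters greatly, although chloro and methyl each count one heavy atom, and methyl gives the highest number of the three compounds. As far as these compounds go, whether an amine, a methoxy group or a longer chain here would give a number nearer compound 2 or compound 3 stays open. So does whether bromo would lower the number further. Nothing available explains the size of this change.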